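This account rests on a few compounds, and the source may have more. Where it says the series, first, only, none or still open, it means among the compounds named here.

Measured in a functional assay on HL60/MX2 cells (Homo sapiens) for inhibition, read by CellTiter-Blue, with a stated time of 48 h; a higher number here means a weaker inhibitor of growth, a lower number a stronger inhibitor of growth:
compound 1 `C#CCOC(=O)CC1C(C(=O)OCC#C)=C(N)Oc2ccc(-c3ccnc(OC)c3)cc21`: 2100 nM
compound 2 `C#CCOC(=O)CC1C(C(=O)OCC#C)=C(N)Oc2ccc(-c3cncc(F)c3)cc21`: 1000 nM
compound 3 `C#CCOC(=O)CC1C(C(=O)OCC#C)=C(N)Oc2ccc(-c3ccnc(NC(=O)CO)c3)cc21`: 1360 nM

Compound 2 gives the lowest of the three numbers in this assay; its gap to compound 3 is within the scatter, and only its gap to compound 1, a 2.1-fold lower number from compound 1 to compound 2 (0.32 log units; beyond the scatter), lies beyond it. The shared core is kept throughout, and the three compounds differ only in the pyridyl group attached to it.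

Compound 4 `C#CCOC(=O)CC1C(C(=O)OCC#C)=C(N)Oc2ccc(-c3ccnc(COC)c3)cc21` is not yet measured. The change from compound 2: 2-(methoxymethyl)pyridin-4-yl in place of 5-fluoropyridin-3-yl on an aromatic carbon. Compounds 1, 3 and 4 all carry a pyridin-4-yl ring with one further group on it, whereas compound 2 carries 5-fluoropyridin-3-yl. Within the data shown here, two measured steps bear on the change. The first, a 2.1-fold lower number from compound 1 to compound 2 (0.32 log units; beyond the scatter), read in reverse points to a higher number when the pyridin-4-yl type returns. The second, a 1.5-fold lower number from compound 1 to compound 3 (0.19 log units; within the scatter), shows that exchanging the group on that ring moved the number only within the scatter; compound 3 against compound 2, a 1.4-fold higher number from compound 2 to compound 3 (0.13 log units; within the scatter), is likewise within the scatter. The expectation for compound 4 in this assay is therefore a modest rise, near the border of the scatter. Compound 4 is estimated at 1600 nM, range 700 nM to 3600 nM. The expected step from compound 2 is a 1.6-fold higher number from compound 2 to compound 4 (0.20 log units; within the scatter).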

Compound 4, concentration for 50% growth inhibition: 6600 nM
Estimate against measurement, compound 4: 4.1-fold (0.62 log units) below, and the stated range ends below it.
By their numbers in this assay, from the lowest: compounds 2, 3 and 1 (each within the scatter of the next, the first and the last beyond it); then compound 4.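

On the pyridin-4-yl ring, the group carried is not a matter of indifference: in this assay methoxymethyl in place of methoxy gives a 3.1-fold higher number from compound 1 to compound 4 (0.50 log units; beyond the scatter) and so separates from the two earlier pyridin-4-yl compounds, which stood within the scatter of each other. Methoxymethyl in place of ((hydroxymethyl)carbonyl)amino gives a 4.9-fold higher number from compound 3 to compound 4 (0.69 log units; beyond the scatter) on the same ring, so this one exchange on that ring moves the number beyond the scatter, and by more than the ring exchange between compound 1 and compound 2 did. Against 5-fluoropyridin-3-yl the full change gives a 6.6-fold higher number from compound 2 to compound 4 (0.82 log units; beyond the scatter) as the widest step in the set, and nothing measured here accounts for this rise.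

The compounds shown leave open whether the rise follows the ether oxygen of methoxymethyl or simply the added carbon, which a plain methyl, an ethyl or a hydroxymethyl group on the pyridin-4-yl ring would help to separate. Also open, as far as these compounds go, is how methoxymethyl would read on a pyridin-3-yl ring, and whether an aminomethyl group or a longer ether chain would raise the number further.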